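The source may report more compounds than this note shows. Statements on the series, on what has been measured and on what is new or still open speak of the compounds shown alone.

The compounds below were tested in a functional assay on PC-3 cells (Homo sapiens) for cytotoxicity, read by MTT assay, with a stated time of 72 h (on this read-out higher numbers stand for weaker inhibition and lower numbers for stronger inhibition), and gave these results.

- compound 1 `CNC(=O)c1cc(Oc2ccc(C(=O)/C=C/c3cccc(Br)c3)cc2)ccn1` gives 3400 nM
- compound 2 `CNC(=O)c1cc(Oc2ccc(C(=O)/C=C/c3ccc(OC)c(OC)c3OC)cc2)ccn1` gives "not determined" (no result reported)
- compound 3 `CNC(=O)c1cc(Oc2ccc(C(=O)/C=C/c3ccc([N+](=O)[O-])cc3)cc2)ccn1` gives 11100 nM

Only two of these compounds have a number, and compound 3 holds the higher one, so it is the weaker inhibitor of that pair. Its nearest neighbour is compound 1, while compound 2 offers no number to compare.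

The next compound is compound 4 `CNC(=O)c1cc(Oc2ccc(C(=O)/C=C/c3ccccc3)cc2)ccn1`. It has hydrogen in place of nitro on an aromatic carbon, para to a large group, which turns 4-nitrophenyl into phenyl (hydrogen in place of nitro on an aromatic carbon).

Among the compounds with values here, one measured step bears on this change, and it involves the same end of the molecule. With 4-nitrophenyl in place of 3-bromophenyl, the result is a 3.3-fold higher number from compound 1 to compound 3 (0.51 log units; beyond the scatter), a modest step. Within the data shown here, compound 4 carries neither group, and no measured pair shows what happens when a group is simply removed, so the evidence is indirect. Compound 3 stands at the top of the measured numbers, so a small move toward a lower number in this assay seems more likely than a further rise.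

The expected change is a 2.2-fold lower number from compound 3 to compound 4 (0.35 log units; beyond the scatter). For compound 4 the estimated value is 5000 nM, with an expected range from 1700 nM to 15000 nM.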

Compound 4, half-maximal inhibitory concentration: 3170 nM
Beside the measured number, compound 4's estimate is 1.6-fold (0.20 log units) above it; the range from low to high includes it.
By their numbers in this assay, from the lowest: compounds 4 and 1 (each within the scatter of the next); then compound 3.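

In this assay the swap of hydrogen for nitro, on the aromatic carbon para to a large group, gives a 3.5-fold lower number from compound 3 to compound 4 (0.54 log units; beyond the scatter) and so shows directly that the plain phenyl compound inhibits more strongly than its 4-nitrophenyl partner. The second comparison, hydrogen in place of bromo, gives a 1.1-fold lower number from compound 1 to compound 4 (0.03 log units; within the scatter) and lies within the scatter, so the phenyl and 3-bromophenyl compounds cannot be told apart on these numbers, and only the nitro group goes with a real change. Nothing at hand explains why nitro and bromo differ in this way.

Bromo and nitro also sit on different ring carbons, so these compounds cannot separate the identity of the group from its place on the ring, and a 4-bromophenyl compound would help to settle that. On these data alone, it also remains open whether other groups at the nitro position, such as an amine or a carboxylic acid, would match the phenyl compound or shift the number in either direction.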